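The compounds below may be only part of what the source reports. "The series", "measured", "known", "first", "only" and "open" are said of these compounds alone.

Compound 1 `Cc1ccc(-n2cc(C(=O)Nc3cc(F)cc(F)c3)c(=O)c3ccc(N(C)C)nc32)cc1OCCCCCCC[N+]1(C)CCCCC1` gives 23.4% in an assay on LX2 cells for inhibition of COL1A1 promoter (Homo sapiens), read by a luciferase reporter, with a stated time of 24 h, tested at 20 uM; on this read-out lower numbers stand for a weaker effect and higher numbers for a stronger effect at the one concentration tested. Compound 2 `CN(C)c1ccc2c(=O)c(C(=O)Nc3cc(F)cc(F)c3)cn(-c3ccc(Cl)c(OCCCCCCC[N+]4(C)CCCCC4)c3)c2n1` gives 57.3% in this assay. Compound 3 `Cc1cc(OCCCCCCC[N+]2(C)CCN(C)CC2)cc(-n2cc(C(=O)Nc3cc(F)cc(F)c3)c(=O)c3ccc(N(C)C)nc32)c1` gives 2.8% in this assay. Among these three, compound 2 stands highest: its nearest neighbour is compound 1, and the single step that separates the two is a number 33.9 percentage points higher from compound 1 to compound 2 (beyond the scatter), a large rise that lies beyond the scatter. Compound 3 lies furthest from compound 2, also beyond the scatter, but it differs from compound 2 in more than one place, so its value can only be taken on its own.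

Compound 4 `CC[N+]1(CCCCCCCOc2cc(-n3cc(C(=O)Nc4cc(F)cc(F)c4)c(=O)c4ccc(N(C)C)nc43)ccc2Cl)CCCC1` is built from the same atoms as compound 2, joined differently: a group of 7 heavy atoms (6 carbon, 1 nitrogen; one five-membered non-aromatic ring with 1 hetero atom) in place of a group of 7 heavy atoms (6 carbon, 1 nitrogen; one six-membered non-aromatic ring with 1 hetero atom), on a saturated chain carbon, seven bonds along the chain from an oxygen on an aromatic ring. Within the data shown here, no measured step alters the charged ring at the chain end alone, so the one recorded step, which concerns the aromatic substituent, does not bear on this change. With nothing in the data to point either way, the expected step is a number 5.3 percentage points lower from compound 2 to compound 4 (within the scatter), that is, no change beyond the scatter. Compound 4 is therefore estimated at 52% in this assay, within a range from 28% to 74%.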

Compound 4, a percentage reported as inhibition, at one concentration (the size of the read-out at that concentration, not a potency): 46%
Compound 4: middle estimate off by 6 percentage points, on the high side, within the range that was stated.
By their numbers in this assay, from the lowest: compound 3; then compound 1; then compound 4; then compound 2.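

Among these compounds, with compound 4, the charged group at the chain end is changed on its own for the first time, and the step is a number 11.3 percentage points lower from compound 2 to compound 4 (beyond the scatter) in this assay. The earlier step concerned only the aromatic substituent, whereas this one shows that the saturated chain position, seven bonds along the chain from an oxygen on an aromatic ring, is sensitive to swapping the six-membered non-aromatic ring group for the five-membered one, even though both groups have the same heavy-atom count, net charge and hydrogen-bond counts. Nothing in the material at hand accounts for this modest drop.

The compounds shown leave open how a morpholine ring or an open trimethylammonium group at the same chain end would read in this assay, and whether a shorter chain would hold the value. They also leave open whether the same ring swap would give a step of similar size with methyl in place of chloro on the aromatic carbon, as in compound 1.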